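The source may hold more compounds than are shown below. What is called first, only, known or untested is meant among the compounds shown, and "the series" means these compounds.

Series in a functional assay on KB cells (Homo sapiens) for antiproliferative activity, read by sulforhodamine B assay, with a stated time of 3 days; a higher number here means that more compound is needed for the effect, a lower number that less compound is needed:
- compound 1 `CCCCc1ccc(-c2cc(=O)c3c(o2)C(CC)(CC)C(=O)C(CC)=C3O)cc1` gives 111 uM
- compound 2 `CCC1=C(O)c2c(oc(-c3ccc(CC(C)C)cc3)cc2=O)C(CC)(CC)C1=O` gives 29.3 uM
- compound 3 `CCOc1ccc(-c2cc(=O)c3c(o2)C(CC)(CC)C(=O)C(CC)=C3O)cc1` gives > 52.4 uM

Compound 3 has no number, only an assay limit, as noted in the limit of > 52.4 uM in this assay, at which 1 of the 3 values shown sits.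

Compound 4 `CCC1=C(O)c2c(oc(-c3cccc(OC)c3)cc2=O)C(CC)(CC)C1=O` is unmeasured and carries 3-methoxyphenyl in place of 4-ethoxyphenyl on an aromatic carbon, (3-methoxyphenyl in place of 4-ethoxyphenyl on an aromatic carbon).

The nearest evidence comes from changes to the same aromatic substituent. One is modest and beyond the scatter, a 3.8-fold lower number from compound 1 to compound 2 (0.58 log units; beyond the scatter). Another has a floor within the scatter, an at least 1.7-fold higher number from compound 2 to compound 3 (0.25 log units; that floor lies within the scatter). A third is unreadable, a step that the limit leaves unreadable from compound 1 to compound 3. Within the data shown here, no measured compound carries 3-methoxyphenyl.

No step beyond the scatter is expected, and the estimated step is a step that the limit leaves unreadable from compound 3 to compound 4.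

The estimate for compound 4 is 55 uM, with an expected range of 22 uM to 130 uM.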

Compound 4, concentration for half-maximal effect: 13.3 uM
For compound 4 the middle estimate is 4.1-fold (0.62 log units) above the measured one; measured number outside the range, below it.
By their numbers in this assay, from the lowest: compound 4; then compound 2; then compound 1.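

At this aromatic carbon, this assay shows an at least 3.9-fold lower number from compound 3 to compound 4 (0.59 log units; beyond the scatter), so an ether-bearing phenyl here is compatible with a clearly lower number. The change alters both the ether chain and its place on the phenyl ring, so the step cannot be assigned to either alone. Compound 3 carries an assay limit, so the size of this step is only a floor: the limit of > 52.4 uM in this assay, at which 1 of the 4 values shown sits.

4-Methoxyphenyl and 3-ethoxyphenyl would separate those two changes. From the compounds shown here alone, how an amine or a carboxylic acid on this phenyl ring would read remains open.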